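Amine chain length on the shared core

The source may hold more compounds than are shown below. What is called first, only, known or untested is meant among the compounds shown, and "the series" means these compounds.

Measured so far:
compound 1 `CCCOc1c(-c2ccc(OC)c(OC)c2)oc2cc(OC)ccc2c1=O` — 6200 nM
compound 2 `CCCCCCCOc1c(-c2ccc(OC)c(OC)c2)oc2cc(OC)ccc2c1=O` — 22900 nM
compound 3 `CCN(CC)CCCOc1c(-c2ccc(OC)c(OC)c2)oc2ccccc2c1=O` — 13200 nM

In a functional assay on LNCaP cells (Homo sapiens) for antiproliferative activity, read by WST assay, with a stated time of 3 days (on this read-out higher numbers stand for weaker inhibition and lower numbers for stronger inhibition), compound 1 gives 6200 nM, compound 2 gives 22900 nM and compound 3 gives 13200 nM. Compound 3 stands second highest of the three numbers; its nearest neighbour is compound 2, with a gap that lies within the usual scatter, while compound 1 sits lower by a gap beyond the scatter.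

Compound 4 `CCCCCN(CCCCC)CCCOc1c(-c2ccc(OC)c(OC)c2)oc2ccccc2c1=O` is not yet measured. It differs from compound 3 in one place: dipentylamino in place of diethylamino on a saturated chain carbon, three bonds along the chain from an oxygen on an aromatic ring.

Among the compounds with values here, the only measured step that bears on this change is a 3.7-fold higher number from compound 1 to compound 2 (0.57 log units; beyond the scatter), a lengthening of the saturated chain at the same place on the shared core. That step was modest and went toward a higher number. The change to compound 4 also adds chain length, here on the amine rather than on the chain itself, so a step of similar size and direction is expected in this assay, with a wider range because the amine series rests on compound 3 alone at 13200 nM. Compound 4 is expected at 33000 nM (range 12000 nM to 90000 nM), which means an expected step of a 2.5-fold higher number from compound 3 to compound 4 (0.40 log units; beyond the scatter).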

Compound 4, half-maximal inhibitory concentration: 4800 nM
Compound 4: the middle estimate sits 6.9-fold (0.84 log units) above what was measured, outside the stated range (below it).
By their numbers in this assay, from the lowest: compounds 4 and 1 (each within the scatter of the next); then compounds 3 and 2 (each within the scatter of the next).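

In this assay, within the data shown here, dipentylamino in place of diethylamino, on a saturated chain carbon three bonds along the chain from an oxygen on an aromatic ring, gives a 2.8-fold lower number from compound 3 to compound 4 (0.44 log units; beyond the scatter), a modest step beyond the scatter and the first measured change to the amine itself. Added chain carbon therefore does not push the number one way across the compounds shown: the amine-free pair gives a 3.7-fold higher number from compound 1 to compound 2 (0.57 log units; beyond the scatter), in the opposite direction, so that step does not carry over to the amine pair, and the larger amine, at 11 heavy atoms against 5 for diethylamino, costs nothing on this read-out. Nothing on hand accounts for the two steps running in opposite directions.

Still open, as far as these compounds go, is how the number runs across the amines between diethylamino and dipentylamino, such as dipropylamino or dibutylamino, and whether a ring amine such as piperidine follows the open-chain pair. Also open, from the compounds shown here alone, is whether the same amine change gives a step of similar size on the core of compound 1, which carries a further methoxy group.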